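A butoxy group added to a cytotoxicity-tolerant scaffold

The source may hold more compounds than are shown below. What is called first, only, known or untested is meant among the compounds shown, and "the series" means these compounds.

Three compounds built on a shared core have been examined in a toxicity assay on MDCK cells (Canis lupus familiaris) for cytotoxicity, read by crystal violet staining, with a stated time of 48 h; a higher number here means that more compound is tolerated, a lower number that less compound is tolerated. Compound 1 `CCCCC(c1cc2ccc(C)cc2[nH]c1=O)N(Cc1ccc(F)cc1)Cc1ccc(C(C)C)cc1` gives > 33000 nM in this assay, which is a limit of the assay and not a number. Compound 2 `Cc1ccc2[nH]c(=O)c(CN(Cc3ccccc3)Cc3ccc(C(C)(C)C)cc3)cc2c1` gives > 5000 nM in this assay, likewise a limit. Compound 3 `CCc1ccc2[nH]c(=O)c(CN(Cc3cccc(F)c3)Cc3ccc4ccccc4c3)cc2c1` also gives > 5000 nM in this assay, again only a limit. Compound 2 therefore sits at the limit of > 5000 nM in this assay, at which 2 of the 3 values shown sit, whereas the limit of > 33000 nM in this assay, at which 1 of the 3 values shown sits, belongs to compound 1 alone; because every result so far is a limit, none of the three compounds can be ranked against the others.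

Compound 4 `CCCCOc1ccc(CN(Cc2ccc(C(C)(C)C)cc2)Cc2cc3cc(C)ccc3[nH]c2=O)cc1` has not yet been measured in this assay. It differs from compound 2 by butoxy in place of hydrogen on an aromatic carbon. For the measured compounds named here, no step between two measured compounds with this kind of change exists, so there is no direct precedent for its effect on cytotoxicity. With all three measured compounds tolerated up to their respective limits, the step that the limit leaves unreadable from compound 2 to compound 4 is expected to be none beyond the usual scatter. Compound 4 is thus estimated to give 10000 nM in this assay, with a likely range from 3000 nM to 50000 nM, and most probably it too will be reported only as a limit.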

Compound 4, half-maximal cytotoxic concentration: > 5000 nM
Compound 4: no number, only a limit; the forecaster's own chance of this, stated with the estimate: 75%; the middle value does not contradict the limit.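

The step from compound 2 to compound 4 cannot be read: both results in this assay are limits of the assay and not numbers. The compounds shown leave open the concentration at which any of them becomes cytotoxic, and whether butoxy in place of hydrogen on an aromatic carbon changes how much compound is tolerated.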